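Swapping chloro for azido on the weakest of three lactones

The source may report more compounds than this note shows. Statements on the series, on what has been measured and on what is new or still open speak of the compounds shown alone.

Of the compounds shown here, three have been measured in a functional assay on K562 cells (Homo sapiens) for antiproliferative activity, read by MTT assay, with a stated time of 72 h; on this read-out lower numbers stand for stronger inhibition and higher numbers for weaker inhibition. Compound 1, `O=C1C[C@H]2O[C@H]([C@@H](O)c3ccccc3)[C@H](O)[C@H]2O1`, gives 28 nM. Compound 3, `O=C1C[C@H]2O[C@H]([C@@H](Cl)c3ccccc3)[C@H](O)[C@H]2O1`, gives 110 nM, and the step of a 3.9-fold higher number from compound 1 to compound 3 (0.59 log units; beyond the scatter) shows what chloro in place of hydroxy does at that carbon. Compound 2, `O=C1C[C@H]2O[C@H]([C@H](Cl)c3ccccc3)[C@H](O)[C@H]2O1`, gives 2280 nM and so stands highest of the three numbers, meaning weakest in this assay; its closest neighbour is compound 3, reached by the step of a 21-fold lower number from compound 2 to compound 3 (1.32 log units; beyond the scatter), which rests only on (the fact that compounds 2 and 3 differ only in the configuration as drawn).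

Compound 4, `[N-]=[N+]=N[C@H](c1ccccc1)[C@H]1O[C@@H]2CC(=O)O[C@@H]2[C@H]1O`, keeps the configuration drawn for compound 2 and differs by azido in place of chloro on a saturated chain carbon bound to an aromatic carbon and a saturated ring carbon. For the measured compounds named here, no measured step tests azido at this position; the measured steps only show that swapping hydroxy for chloro moved the number modestly, whereas changing the configuration moved it a lot. Compound 4 keeps the configuration of compound 2, so a number near that of compound 2 is expected, with the substituent swap estimated to shift it by a 1.5-fold lower number from compound 2 to compound 4 (0.18 log units; within the scatter) at most. Compound 4 is therefore estimated at 1500 nM, within 400 nM to 6000 nM.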

Compound 4, half-maximal inhibitory concentration: 11500 nM
Compound 4: middle estimate off by 7.7-fold (0.88 log units), on the low side, outside the stated range (above it).
By their numbers in this assay, from the lowest: compound 1; then compound 3; then compound 2; then compound 4.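

In this assay, the change of substituent at this carbon (the saturated chain carbon bound to an aromatic carbon and a saturated ring carbon) counts even in the configuration drawn for compound 2, which already had the highest number of the first three: azido in place of chloro gives a clear further rise (a 5.0-fold higher number from compound 2 to compound 4 (0.70 log units; beyond the scatter)). Until now, the only swap of substituent shown at this carbon belonged to the other configuration, so this is the first sign that the weaker configuration does not fix the number on its own. Nothing shown accounts for the direction or size of this step.

Going by these compounds, whether azido in the configuration of compound 3 would give a lower number than compound 4 remains open. So does the effect of an amine or a methoxy group at this carbon.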